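Arylidene series: a second methoxy on the pendant ring

The source may hold more compounds than are shown below. What is called first, only, known or untested is meant among the compounds shown, and "the series" means these compounds.

Measured so far in a functional assay on Jurkat cells (Homo sapiens) for antiproliferative activity, read by MTT assay; a lower number here means a stronger inhibitor, a higher number a weaker inhibitor:
compound 1, `COc1ccccc1/C=C1\CCc2cc(OC)c(OC)cc2C1=O`, gives > 50000 nM.
compound 2, `COc1ccc(/C=C2\CCc3cc(OC)c(OC)cc3C2=O)cc1`, gives > 50000 nM.
compound 3, `COc1cc2c(cc1OC)C(=O)/C(=C/c1ccc(O)cc1)CC2`, gives 19000 nM.

Compound 1 stands at the top of the numbers shown: its value is a limit of this assay, not a number. Compound 2 also reports only a limit. (the limit of > 50000 nM in this assay, at which 2 of the 3 values shown sit). Compound 3 alone returns a number, and the steps to it read an at least 2.6-fold lower number from compound 1 to compound 3 (0.42 log units; beyond the scatter) and an at least 2.6-fold lower number from compound 2 to compound 3 (0.42 log units; beyond the scatter), while the step that the two limits leave unreadable from compound 1 to compound 2 cannot be read.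

Compound 4, `COc1cc2c(cc1OC)C(=O)/C(=C/c1c(OC)cccc1OC)CC2`, differs from compound 1 by methoxy in place of hydrogen on an aromatic carbon. For the measured compounds named here, none of the measured steps changes the pendant ring in this way; the readable steps both concern a hydroxyl replacing a methoxy, which is not what happens here. Going by the values given here, with no step bearing directly on the change, the expectation for compound 4 in this assay is a step that the limit leaves unreadable from compound 1 to compound 4, most likely again a limit. Compound 4 is thus estimated at 60000 nM, within 25000 nM to 150000 nM.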

Compound 4, half-maximal inhibitory concentration: > 50000 nM
Compound 4 ended at the assay's limit; the forecaster's own chance of this, stated with the estimate: 75%; the middle value does not contradict the limit.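

In this assay compound 4 gives > 50000 nM as a limit, not a number. Compound 1 also reports only a limit, so no new step can be read between compound 1 and compound 4: the limit of > 50000 nM in this assay, at which 3 of the 4 values shown sit.

The compounds shown leave open what methoxy in place of hydrogen on an aromatic carbon does to the number in this assay when both partners lie inside the readable range.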